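The source may hold more compounds than are shown below. What is called first, only, known or untested is meant among the compounds shown, and "the series" means these compounds.

In a functional assay on A549 cells (Homo sapiens) for cytotoxicity, read by MTT assay, with a stated time of 48 h (a higher number here means a weaker inhibitor, a lower number a stronger inhibitor), compound 1 `C=C1CCC[C@]2(C)CCC(c3cn(-c4ccc(OC)cc4)nn3)=CC[C@@]12C` gives 34700 nM. Two relatives share its core and differ only in the group on an aromatic nitrogen: compound 2 `C=C1CCC[C@]2(C)CCC(c3cn(-c4cccc([N+](=O)[O-])c4)nn3)=CC[C@@]12C` gives 24700 nM, and compound 3 `C=C1CCC[C@]2(C)CCC(c3cn(-c4ccccc4C(C)=O)nn3)=CC[C@@]12C` gives 37700 nM. Compound 1 therefore stands level with both, as all three numbers lie within the usual scatter of repeated measurements.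

Compound 4 `C=C1CCC[C@]2(C)CCC(c3cn(-c4ccc(C)cc4)nn3)=CC[C@@]12C` makes one small change to compound 1: methyl in place of methoxy on an aromatic carbon. In words, it has methyl in place of methoxy on an aromatic carbon, para to a large group. Among the measured compounds shown here, no measured step makes this exact swap. The closest evidence comes from replacing the whole substituted phenyl group: a 1.4-fold lower number from compound 1 to compound 2 (0.15 log units; within the scatter), a 1.1-fold higher number from compound 1 to compound 3 (0.04 log units; within the scatter) and a 1.5-fold higher number from compound 2 to compound 3 (0.18 log units; within the scatter). Each of these larger swaps stayed within the scatter, so no step beyond the scatter is expected in this assay, and no direction can be favoured. The expected step is a 1.1-fold lower number from compound 1 to compound 4 (0.02 log units; within the scatter). Compound 4 is estimated at 33000 nM, with an expected range from 20000 nM to 52000 nM.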

Compound 4, half-maximal inhibitory concentration: 58800 nM
For compound 4 the middle estimate is 1.8-fold (0.25 log units) below the measured one, and the stated range ends below it.
By their numbers in this assay, from the lowest: compounds 2, 1, 3 and 4 (each within the scatter of the next, the first and the last beyond it).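

Methyl in place of methoxy, on the aromatic carbon para to a large group, is the first change here that leaves the rest of the phenyl group untouched, and this assay shows a 1.7-fold higher number from compound 1 to compound 4 (0.23 log units; within the scatter) for this swap. So this small change stays level, as the larger swaps of the whole substituted phenyl group did. Among the compounds shown here, the step of a 1.6-fold higher number from compound 3 to compound 4 (0.19 log units; within the scatter) also stays level, whereas the step of a 2.4-fold higher number from compound 2 to compound 4 (0.38 log units; beyond the scatter) is the first in this set to pass beyond the scatter, though only modestly. Nothing available explains this gap.

The compounds shown leave open whether an amine, a carboxylic acid or a longer chain on that same aromatic carbon would separate clearly from compound 1. They also leave open whether the one modest gap would hold in repeated measurements.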